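The source may report more compounds than this note shows. Statements on the series, on what has been measured and on what is new or still open speak of the compounds shown alone.

Measured so far in an ADME assay on L6 cells (Rattus norvegicus) for cytotoxicity, read by fluorescence and resazurin assay, with a stated time of 70 h; a lower number here means a stronger inhibitor, a higher number a weaker inhibitor:
compound 1 `N=C(N)Nc1ccc2[nH]c(-c3ccc(-c4ccccc4)cc3)nc2c1`: 46.2 ug/mL
compound 2 `N=C(N)Nc1ccc2[nH]c(-c3ccc(OCc4ccccc4)cc3)nc2c1`: 43.2 ug/mL

Going by the values given here, compound 2, at 43.2 ug/mL, stands within the scatter of compound 1, the only other measured compound. Compound 3 `COc1ccc(Oc2ccc(-c3nc4cc(NC(=N)N)ccc4[nH]3)cc2)cc1OC` is unmeasured and differs from compound 2 on the oxygen: 3,4-dimethoxyphenyl in place of benzyl on an oxygen on an aromatic ring, with 3,4-dimethoxyphenyl in place of benzyl on an oxygen on an aromatic ring. Among the compounds with values here, the only measured step is a 1.1-fold lower number from compound 1 to compound 2 (0.03 log units; within the scatter), with benzyloxy in place of phenyl on an aromatic carbon. It lies within the scatter, but it is a different change, so it offers only weak guidance. Within the data shown here, no measured compound carries the 3,4-dimethoxyphenyl group. No step beyond the scatter is expected in this assay. The expected change is a 1.1-fold lower number from compound 2 to compound 3 (0.03 log units; within the scatter). For compound 3 the estimate is 40 ug/mL, with an expected range of 18 ug/mL to 80 ug/mL.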

Compound 3, half-maximal inhibitory concentration: > 100 ug/mL
Compound 3: only a limit was reported; the forecaster's own chance of this, stated with the estimate: 8%; middle value at least 2.5-fold (0.39 log units) away from the limit.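

In this assay, replacing benzyl with 3,4-dimethoxyphenyl on an oxygen on an aromatic ring gives an at least 2.3-fold higher number from compound 2 to compound 3 (0.36 log units; beyond the scatter), so the group on this oxygen can move the read-out beyond the scatter, which the earlier step, a 1.1-fold lower number from compound 1 to compound 2 (0.03 log units; within the scatter), a different change, did not show. The direction is towards a higher number, and the step's printed size is only a floor. Compound 3 gives > 100 ug/mL, which is a limit and not a number, so its true value stays unknown: the limit of > 100 ug/mL in this assay, at which 1 of the 3 values shown sits.

The change swaps benzyl for an aromatic ring bonded directly to the oxygen and brings in two methoxy groups at once, and the compounds shown do not separate these two features. As far as these compounds go, how an amine or a carboxylic acid on the same ring would read in this assay also remains open.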